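The source may report more compounds than this note shows. Statements on the series, on what has been measured and on what is new or still open speak of the compounds shown alone.

Of the compounds shown here, two have been measured for cytotoxicity, both built on the same core with a urea or amide link to a substituted phenyl ring. Compound 1 `COC(=O)c1ccc2c(ccn2-c2ccc(NC(=O)Nc3ccc(Cl)c(C(F)(F)F)c3)cc2)n1` carries a urea, and in a functional assay on A375P cells (Homo sapiens) for cytotoxicity, read by MTT assay (a lower number here means a stronger inhibitor, a higher number a weaker inhibitor), compound 1 gives 3600 nM. Compound 2 `COC(=O)c1ccc2c(ccn2-c2ccc(NC(=O)c3ccc(Cl)c(C(F)(F)F)c3)cc2)n1` carries an amide in its place, and in this assay compound 2 gives 3000 nM. The two numbers sit within the scatter of each other, so compound 2 cannot be set apart from compound 1 on this evidence. Compound 3 `COC(=O)c1ccc2c(ccn2-c2ccc(NC(=O)Nc3ccc(Cl)c(Cl)c3)cc2)n1` has not been measured. It differs from compound 2 in one place: (3,4-dichlorophenyl)amino in place of 4-chloro-3-(trifluoromethyl)phenyl on a carbonyl carbon. Compound 3 therefore returns to a urea link, as in compound 1, while the trifluoromethyl on the ring becomes a second chlorine. Among the compounds with values here, no step between measured compounds covers this exchange, and the urea and amide of compound 1 and compound 2 lie within the scatter. The expected step of a 1.3-fold higher number from compound 2 to compound 3 (0.12 log units; within the scatter) is accordingly no more than the scatter, in either direction. Compound 3 is estimated at 4000 nM, in a range from 1500 nM to 10000 nM.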

Compound 3, half-maximal inhibitory concentration: 3800 nM
Compound 3: middle estimate off by 1.1-fold (0.02 log units), on the high side, and the stated range covers the measured number.
By their numbers in this assay, from the lowest: compounds 2, 1 and 3 (each within the scatter of the next).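

With the urea link held constant, chloro in place of trifluoromethyl on an aromatic carbon gives a 1.1-fold higher number from compound 1 to compound 3 (0.02 log units; within the scatter) in this assay, so this one exchange on the ring, which the earlier pair did not isolate, does not separate the two compounds. The wider exchange, (3,4-dichlorophenyl)amino in place of 4-chloro-3-(trifluoromethyl)phenyl on a carbonyl carbon, alters the link and the ring substituent together and gives a 1.3-fold higher number from compound 2 to compound 3 (0.10 log units; within the scatter), so this combined change also stays within the scatter of the assay. No evidence is available that bears on these results.

The three compounds leave open whether a group of another kind on that aromatic carbon, such as an amine, a methoxy group or a carboxylic acid, would give a number beyond the scatter, since only chloro and trifluoromethyl appear there. As far as these compounds go, the methyl ester on the shared core is the same throughout, so what a carboxylic acid or a primary amide in its place would give in this assay also remains open.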